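The source may hold more compounds than are shown below. What is called first, only, known or untested is meant among the compounds shown, and "the series" means these compounds.

Compounds measured in an assay on HEK293 cells for agonist activity at transient receptor potential cation channel subfamily M member 8 (Homo sapiens), read by fluorescence and calcium flux, with a stated time of 15 min; a higher number here means that more compound is needed for the effect, a lower number that less compound is needed:
compound 1, `Cc1ccc(OCC(=O)N(Cc2cccs2)CC(C)C)cc1` — 900 nM
compound 2, `CCN(Cc1cccs1)C(=O)COc1ccc(C(C)C)cc1` — 397 nM

Compound 1 holds the highest number of the two in this assay; compound 2 sits at a lower number, and that gap lies beyond the scatter. Compound 3, `CCCN(Cc1cccs1)C(=O)COc1ccc(C)cc1`, is not yet measured. It differs from compound 1 by hydrogen in place of methyl on a saturated chain carbon bound to two saturated chain carbons, which cut one bond further out reads isobutyl to propyl. Going by the values given here, no measured pair shows this change. Such a shortening is expected to move the number little, so the step of a 1.1-fold higher number from compound 1 to compound 3 (0.05 log units; within the scatter) is expected to stay within the scatter. Compound 3 is estimated at 1000 nM, with a range of 400 nM to 2500 nM.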

Compound 3, half-maximal effective concentration: 40 nM
Beside the measured number, compound 3's estimate is 25-fold (1.40 log units) above it, outside the stated range (below it).
By their numbers in this assay, from the lowest: compound 3; then compound 2; then compound 1.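

In this assay, the position on a saturated chain carbon bound to two saturated chain carbons is sensitive to a very small edit: hydrogen in place of methyl, isobutyl to propyl, gives a 23-fold lower number from compound 1 to compound 3 (1.35 log units; beyond the scatter). The loss of a single carbon, with no ring, donor, acceptor or charge involved, is enough for a large step in this series. No measurement at hand accounts for the size of this step.

Still open, on these data alone, is how a butyl chain or a cyclopropylmethyl group would read at this place. As far as these compounds go, whether the step carries over to other substituents on the shared core also remains open.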